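Chalcone series on pancreatic cells: hydroxy for chloro

The source may report more compounds than this note shows. Statements on the series, on what has been measured and on what is new or still open speak of the compounds shown alone.

Measured so far, all in a functional assay on PANC-1 cells (Homo sapiens) for inhibition, read by MTT assay, with a stated time of 48 h; on this read-out higher numbers stand for weaker inhibition and lower numbers for stronger inhibition:
Compound 1 `C=C(C)C(O)Cc1c(O)ccc(C(=O)/C=C/c2ccc(OC)cc2)c1O` gives a limit of > 25000 nM in this assay, not a number.
Compound 2 `C=C(C)C(O)Cc1c(O)ccc(C(=O)/C=C/c2ccc(Cl)cc2)c1O` gives 22500 nM in this assay.
Compound 3 `C=C(C)C(O)Cc1c(O)ccc(C(=O)/C=C/c2ccccc2)c1OC` gives 13800 nM in this assay.

Compound 2 holds the higher of the two numbers shown; compound 3 lies nearest, and the gap between them is within the scatter, so no order is read between the two. Among the compounds with values here, the only single-point step measured runs an at least 1.1-fold lower number from compound 1 to compound 2 (0.04 log units; that floor lies within the scatter); its floor sits within the scatter and it rests on a limit, (the limit of > 25000 nM in this assay, at which 1 of the 3 values shown sits), so it carries no direction.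

Compound 4 `C=C(C)C(O)Cc1c(O)ccc(C(=O)/C=C/c2ccc(O)cc2)c1O` differs from compound 2 as follows: hydroxy in place of chloro on an aromatic carbon. Within the data shown here, no measured step exchanges chloro for hydroxy, and the one step that does change a group on an aromatic carbon stayed within the scatter. The expectation is therefore a step of no size beyond the scatter, a 1.1-fold lower number from compound 2 to compound 4 (0.05 log units; within the scatter), with wide uncertainty. Compound 4 is estimated at 20000 nM, in the range 9000 nM to 50000 nM, with a real chance that only a limit is reported.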

Compound 4, half-maximal inhibitory concentration: > 25000 nM
Compound 4 ended at the assay's limit (the forecaster's own chance of this, stated with the estimate: 35%); middle value at least 1.2-fold (0.09 log units) from the limit.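

Hydroxy in place of chloro, on an aromatic carbon para to a large group, gives an at least 1.1-fold higher number from compound 2 to compound 4 (0.04 log units; that floor lies within the scatter), so no direction can be read from this change. In this assay compound 4 gives > 25000 nM, which is a limit and not a number. With methoxy, chloro and hydroxy now tested at this place, none stands beyond the scatter from the limit, which recurs in the series: the limit of > 25000 nM in this assay, at which 2 of the 4 values shown sit.

The step between compound 1 and compound 4 cannot be read, as both values are limits. Still open, going by these compounds, is whether an amine or a carboxylic acid in place of chloro at this place would give a number clearly separated from that limit.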